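Sulfonyl chain lengthening in the piperazine series

A few compounds are considered here, and "the series" means these few. Any claim that something is new, unique, unknown or untested is made for them only; others in the source may bear on it.

Compound 1 `CCCS(=O)(=O)N1CCN(c2ccc(OCC3CCN(C(=O)OC(C)C)CC3)cn2)CC1` gives 300 nM in a functional assay on CHO-K1 cells for agonist activity at Glucose-dependent insulinotropic receptor (Homo sapiens), read by a luciferase reporter, with a stated time of 5 h; a higher number here means that more compound is needed for the effect, a lower number that less compound is needed. Compound 2 `CCCCS(=O)(=O)N1CCN(c2ccc(OCC3CCN(C(=O)OC(C)C)CC3)cn2)CC1` differs from it by methyl in place of hydrogen on a saturated chain carbon, three bonds along the chain from a sulfonyl sulfur and gives 100 nM, a step of a 3.0-fold lower number from compound 1 to compound 2 (0.48 log units; beyond the scatter). Compound 3 `CCS(=O)(=O)N1CCN(c2ccc(OCCC3CCN(C(=O)OC(C)C)CC3)cn2)CC1` gives 1200 nM in this assay, the highest number of the three; the difference between the core of compound 3 and the core of compound 1 is not broken down here. Compound 4 `CCCS(=O)(=O)N1CCN(c2ccc(OCCC3CCN(C(=O)OC(C)C)CC3)cn2)CC1` has not been measured. It differs from compound 3 by methyl in place of hydrogen on a saturated chain carbon, two bonds along the chain from a sulfonyl sulfur. This is the same kind of change as that between compound 1 and compound 2, though the place differs: there the methyl enters three bonds along the chain from a sulfonyl sulfur, here two bonds along the chain from a sulfonyl sulfur. For compound 4 the expected step is a 2.7-fold lower number from compound 3 to compound 4 (0.43 log units; beyond the scatter), which rests on a 3.0-fold lower number from compound 1 to compound 2 (0.48 log units; beyond the scatter). Compound 4 is thus estimated at 450 nM, expected to lie between 200 nM and 1000 nM.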

Compound 4, half-maximal effective concentration: 700 nM
Estimate against measurement, compound 4: 1.6-fold (0.19 log units) below; low and high end bracket the measured number.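

On the core of compound 3, methyl in place of hydrogen on a saturated chain carbon, two bonds along the chain from a sulfonyl sulfur, gives a 1.7-fold lower number from compound 3 to compound 4 (0.23 log units; within the scatter) in this assay. Set beside the same change on the core of compound 1, the two steps cannot be told apart: the same change on two cores in this assay, a 3.0-fold lower number (0.48 log units; beyond the scatter) from compound 1 to compound 2 and a 1.7-fold lower number (0.23 log units; within the scatter) from compound 3 to compound 4, 1.8-fold (0.24 log units) apart, within the scatter of two such steps. Among the compounds shown here, this is compatible with the change carrying over between these two cores, but it does not establish transfer: the new step alone is within the scatter, the methyl enters at a different place on each chain, and there are only two pairs.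

Open, from the compounds shown here alone, is how a longer chain such as pentyl on the sulfonyl would read on either core. Going by these compounds, a cyclopropyl group or a terminal amine at the chain end is equally open.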